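The source may hold more compounds than are shown below. What is called first, only, known or untested is meant among the compounds shown, and "the series" means these compounds.

Measured so far:
Compound 1 `Cc1cc(-c2ccc(F)cc2)c(S(C)(=O)=O)cc1C(=O)N=C(N)N` gives 36 nM in a functional assay for inhibition of sodium/hydrogen exchanger (Oryctolagus cuniculus); a higher number here means a weaker inhibitor, a lower number a stronger inhibitor.
Compound 2 `Cc1cc(Sc2ccncc2)c(S(C)(=O)=O)cc1C(=O)N=C(N)N` gives 13 nM in this assay.

Among the compounds with values here, compound 2 holds the lower of the two numbers, and the only measured step leads to it: a 2.8-fold lower number from compound 1 to compound 2 (0.44 log units; beyond the scatter), where a (pyridin-4-yl)sulfanyl group took the place of a 4-fluorophenyl group on the shared core.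

Compound 3 `Cc1cc(OC2CCCCC2)c(S(C)(=O)=O)cc1C(=O)N=C(N)N` has not yet been measured. It differs from compound 2 in one place: cyclohexyloxy in place of (pyridin-4-yl)sulfanyl on an aromatic carbon. Within the data shown here, the group that enters has no counterpart among the measured compounds, which so far carry only a 4-fluorophenyl or a (pyridin-4-yl)sulfanyl group at that position. Among the measured compounds shown here, the single known step, from a carbon-linked ring to a sulfur-linked ring, changed the number only modestly, so the position appears to tolerate some variation, but nothing measured tells how an oxygen-linked saturated ring behaves there. For compound 3 a modest rise in the number is expected, a 2.7-fold higher number from compound 2 to compound 3 (0.43 log units; beyond the scatter), with wide uncertainty. The estimate for compound 3 in this assay is 35 nM, with a likely range from 9 nM to 140 nM.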

Compound 3, half-maximal inhibitory concentration: 37 nM
Estimate against measurement, compound 3: 1.1-fold (0.02 log units) below; measured number inside the range.
By their numbers in this assay, from the lowest: compound 2; then compounds 1 and 3 (each within the scatter of the next).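

The position accepts a saturated carbon ring joined through oxygen: in this assay, cyclohexyloxy in place of (pyridin-4-yl)sulfanyl gives a 2.8-fold higher number from compound 2 to compound 3 (0.45 log units; beyond the scatter) even though the two groups have the same heavy-atom count, so that count alone does not set the number here. Cyclohexyloxy and 4-fluorophenyl differ in both their linking atom and their ring type, yet the comparison shows a 1.0-fold higher number from compound 1 to compound 3 (0.01 log units; within the scatter) and gives no sign of a difference between them, so an aromatic ring directly on the core is not needed to reach the number seen for compound 1. Among these three compounds, only compound 2, with its (pyridin-4-yl)sulfanyl group, stands apart from the others, and nothing available explains why.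

The compounds shown change the linking atom and the ring together, leaving open whether the sulfur link, the pyridine ring or the two combined go with the lower number of compound 2. Nothing shown tells how a phenylsulfanyl group, a pyridin-4-yloxy group or an open-chain butoxy group would compare at this position.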